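This account rests on a few compounds, and the source may have more. Where it says the series, first, only, none or still open, it means among the compounds named here.

Going by the values given here, in a physicochemical assay for solubility, at pH 7.4 (on this read-out lower numbers stand for lower solubility and higher numbers for higher solubility), compound 1 `Cc1cc(NC(=O)Nc2ccc(C)c(Cl)c2)c2ccccc2n1` gives 300 nM and compound 2 `Cc1cc(NC(=O)Nc2ccc(Cl)c(Cl)c2)c2ccccc2n1` gives 300 nM, so these two sit level, together at the low end of the three numbers measured so far. Compound 3 `CCc1ccc(NC(=O)Nc2cc(C)nc3ccccc23)cc1` gives 3300 nM, a number well beyond the scatter from that of compound 2. The next structure is compound 4 `COc1ccc(NC(=O)Nc2cc(C)nc3ccccc23)cc1Cl`, and the change is methoxy in place of chloro on an aromatic carbon, ortho to a chloro group and para to a large group. Among the compounds with values here, only one measured step is a comparable swap on an aromatic carbon: no change at the digits printed from compound 1 to compound 2 (within the scatter). That step involves no methoxy, so it is only a loose guide. Within the data shown here, no measured compound shows what methoxy does here. With compound 3 at 3300 nM, the series clearly can reach higher numbers, so a modest rise in this assay is expected, although no change beyond the scatter remains possible. The expected change is a 2.3-fold higher number from compound 2 to compound 4 (0.37 log units; beyond the scatter). For compound 4 the estimated value is 700 nM, with an expected range from 200 nM to 2500 nM.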

Compound 4, solubility: 400 nM
Compound 4: middle estimate off by 1.8-fold (0.24 log units), on the high side; the measured number falls inside the stated range.
By their numbers in this assay, from the lowest: compounds 1, 2 and 4 (each within the scatter of the next); then compound 3.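

In this assay, on an aromatic carbon ortho to a chloro group and para to a large group, methoxy in place of chloro gives a 1.3-fold higher number from compound 2 to compound 4 (0.12 log units; within the scatter) and methoxy in place of methyl gives a 1.3-fold higher number from compound 1 to compound 4 (0.12 log units; within the scatter) at this same carbon. Until now this position had shown only a swap between chloro and methyl, whereas here a group with two heavy atoms and one hydrogen-bond acceptor enters and compounds 1, 2 and 4 still sit level within the scatter. No measurement shown explains why these three groups give such similar numbers. As far as these compounds go, whether an amine or a carboxylic acid on this carbon would move the number beyond the scatter remains open. So does whether methoxy would behave the same way with the chloro group removed from the ring.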